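The source may report more compounds than this note shows. Statements on the series, on what has been measured and on what is new or still open speak of the compounds shown alone.

Three compounds from this series have been examined in an ADME assay on HEK293 cells (Homo sapiens) for cytotoxicity, read by MTT assay, with a stated time of 24 h; on this read-out higher numbers stand for weaker inhibition and lower numbers for stronger inhibition. Compound 3, `Cc1cc(O)c(C(=O)/C=C/c2ccc(Br)cc2)c(-c2ccc(Br)cc2)c1C(=O)/C=C/c1ccc(Br)cc1`, gives 30000 nM in this assay. Compound 2, `Cc1cc(O)c(C(=O)/C=C/c2ccc(Br)cc2)c(-c2ccccc2)c1C(=O)/C=C/c1ccc(Br)cc1`, gives 10000 nM in this assay. Between the two stands the difference (hydrogen in place of bromo on an aromatic carbon), and the measured step is a 3.0-fold lower number from compound 3 to compound 2 (0.48 log units; beyond the scatter). Compound 1, `Cc1cc(O)c(C(=O)/C=C/c2ccc(F)cc2)c(-c2ccc(Br)cc2)c1C(=O)/C=C/c1ccc(F)cc1`, gives 20000 nM in this assay; its values and those of compounds 3 and 2 lie within the scatter of one another, so no order among the three is asserted. The difference between the core of compound 1 and the core of compound 3 is not broken down here.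

Compound 4, `Cc1cc(O)c(C(=O)/C=C/c2ccc(F)cc2)c(-c2ccccc2)c1C(=O)/C=C/c1ccc(F)cc1`, has not yet been measured. It differs from compound 1 by hydrogen in place of bromo on an aromatic carbon. The site of this change is the same as that of the change from compound 3 to compound 2, and it is the same change. For the measured compounds named here, the expectation for compound 4 therefore rests on the one measured instance: because a 3.0-fold lower number from compound 3 to compound 2 (0.48 log units; beyond the scatter) was seen, a similar step is expected from compound 1, namely a 2.5-fold lower number from compound 1 to compound 4 (0.40 log units; beyond the scatter). Going by the values given here, only one such pair has been measured, so the expected step carries considerable uncertainty, and a result within the scatter of compound 1 would not be surprising. On this basis compound 4 is estimated to give 8000 nM in this assay, with the expected range running from 3000 nM to 20000 nM.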

Compound 4, half-maximal inhibitory concentration: "not active" (no number reported)
For compound 4 the study gives words and no number; no gap can be computed for the estimate.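

In this assay, for the compounds shown here, compound 4 is reported only in words, as not active, with no number, so no step from compound 1 to compound 4 can be read. The compounds shown leave open whether hydrogen in place of bromo changes the number on the core of compound 1 as it does in the measured step, a 3.0-fold lower number from compound 3 to compound 2 (0.48 log units; beyond the scatter). No further data bearing on this result are available.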